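Replacing the furan ring with naphthalene in a coumarin-triazole dienone

A few compounds are considered here, and "the series" means these few. Any claim that something is new, unique, unknown or untested is made for them only; others in the source may bear on it.

Three compounds sharing one core have been measured in a functional assay on THP-1 cells (Homo sapiens) for inhibition, read by sulforhodamine B assay, with a stated time of 48 h, tested at 50 uM; a lower number here means less inhibition of growth, a higher number more inhibition of growth at the concentration tested:

compound 1 `COc1cc(/C=C/C(=O)/C=C/c2cc(OC)c(OC)c(OC)c2)ccc1OCc1cn(CCCCCOc2cc(=O)oc3ccccc23)nn1` gives 55%
compound 2 `COc1cc(/C=C/C(=O)/C=C/c2ccccc2)ccc1OCc1cn(CCCCCOc2cc(=O)oc3ccccc23)nn1` gives 26%
compound 3 `COc1cc(/C=C/C(=O)/C=C/c2ccco2)ccc1OCc1cn(CCCCCOc2cc(=O)oc3ccccc23)nn1` gives 39%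

Compound 3 stands second highest of the three numbers. Above it lies the step of a number 16 percentage points lower from compound 1 to compound 3 (beyond the scatter), and below it the step of a number 13 percentage points higher from compound 2 to compound 3 (beyond the scatter). The widest gap in the set is a number 29 percentage points lower from compound 1 to compound 2 (beyond the scatter), which carries the same kind of change as the other two: only the aryl group on the double-bonded chain carbon bound to a double-bonded chain carbon is varied.

Compound 4 `COc1cc(/C=C/C(=O)/C=C/c2cccc3ccccc23)ccc1OCc1cn(CCCCCOc2cc(=O)oc3ccccc23)nn1` continues this series. naphthalen-1-yl in place of furan-2-yl on a double-bonded chain carbon bound to a double-bonded chain carbon

The step that bears most directly on this change is a number 13 percentage points higher from compound 2 to compound 3 (beyond the scatter), since compound 2 likewise carries a carbon-only aromatic ring in this place and gives 26%. The steps of a number 29 percentage points lower from compound 1 to compound 2 (beyond the scatter) and a number 16 percentage points lower from compound 1 to compound 3 (beyond the scatter) show that compound 1 sits apart from both smaller aryl groups. A modest decrease from compound 3, or no step beyond the scatter, is therefore expected. Compound 4 is expected to give 32% in this assay, within 14% to 52%. The expected step is a number 7 percentage points lower from compound 3 to compound 4 (within the scatter).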

Compound 4, percent growth inhibition at one concentration: 44%
Estimate against measurement, compound 4: 12 percentage points below; the range from low to high includes it.
By their numbers in this assay, from the lowest: compound 2; then compounds 3 and 4 (each within the scatter of the next); then compound 1.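

In this assay, exchanging furan-2-yl for naphthalen-1-yl gives a number 5 percentage points higher from compound 3 to compound 4 (within the scatter), so at this position a five-membered aromatic ring with an oxygen and two six-membered aromatic rings of carbon alone cannot be told apart, while the naphthalen-1-yl group gives a number 18 percentage points higher from compound 2 to compound 4 (beyond the scatter), which shows that a carbon-only aromatic group does not by itself bring the low number of the phenyl compound. The 3,4,5-trimethoxyphenyl group still stands apart, with a number 11 percentage points lower from compound 1 to compound 4 (beyond the scatter), and compound 1 is now the highest of the four, its step to each of the other compounds lying beyond the scatter. No measurement available here accounts for any of these differences.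

The compounds shown leave open whether a single methoxy group on the phenyl ring, a dimethylamino group in its place, or a pyridine ring would reach the number of compound 1 or stay with the others. They also leave open how these four compounds would rank across a range of concentrations, since each has only a growth inhibition reading at a single concentration.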